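The compounds below may be only part of what the source reports. "The series", "measured", "known", "first", "only" and "open" are said of these compounds alone.

Measured so far, in a functional assay on K562 cells (Homo sapiens) for cytotoxicity, read by trypan blue exclusion, with a stated time of 96 h; on this read-out higher numbers stand for weaker inhibition and lower numbers for stronger inhibition:
- compound 1 `O=S(=O)(/C=C/c1c(F)c(F)c(F)c(F)c1F)Nc1c(F)c(F)c(F)c(F)c1F`: 35000 nM
- compound 2 `COC(=O)CNc1cc(NS(=O)(=O)/C=C/c2c(OC)cc(OC)cc2OC)ccc1OC`: 350 nM
- compound 3 `COC(=O)C(Nc1cc(NS(=O)(=O)/C=C/c2c(OC)cc(OC)cc2OC)ccc1OC)c1ccccc1`: 2500 nM

Of these three, compound 3 is second highest at 2500 nM. Its number lies above that of compound 2 and below that of compound 1, and both gaps are beyond the scatter.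

The next compound is compound 4 `COc1cc(OC)c(/C=C/S(=O)(=O)Nc2ccc(OC)c(NC(C(=O)O)c3ccccc3)c2)c(OC)c1`. The change is hydrogen in place of methyl on an oxygen next to a carbonyl group, or methoxycarbonyl to carboxy.

Going by the values given here, only one measured step exists, a 7.1-fold higher number from compound 2 to compound 3 (0.85 log units; beyond the scatter). It is a modest step, and it concerns phenyl in place of hydrogen on a saturated chain carbon, not the change at hand. Among the compounds with values here, no measured pair shows methoxycarbonyl going to carboxy, so the direction rests on judgement alone and the step from compound 2 to compound 3 gives only a rough scale of what one change can do in this assay.

A small move toward a higher number is expected, and a move the other way cannot be excluded. The estimated step is a 2.0-fold higher number from compound 3 to compound 4 (0.30 log units; within the scatter). For compound 4 the expected value is 5000 nM, with an estimated range of 800 nM to 25000 nM.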

Compound 4, half-maximal inhibitory concentration: 300 nM
For compound 4 the middle estimate is 17-fold (1.22 log units) above the measured one, outside the stated range (below it).
By their numbers in this assay, from the lowest: compounds 4 and 2 (each within the scatter of the next); then compound 3; then compound 1.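

In this assay, hydrogen in place of methyl on an oxygen next to a carbonyl group gives an 8.3-fold lower number from compound 3 to compound 4 (0.92 log units; beyond the scatter), so methoxycarbonyl to carboxy moves the number clearly downward when the phenyl on the saturated chain carbon is present. Compound 2 to compound 3 had shown only that adding this phenyl to the ester raises the number, whereas a 1.2-fold lower number from compound 2 to compound 4 (0.07 log units; within the scatter) shows that carboxy(phenyl)methyl and (methoxycarbonyl)methyl on the nitrogen on an aromatic ring cannot be told apart in this read-out, and the phenyl therefore carries no measurable cost once the ester has become the carboxy group. No measurement at hand bears on why the carboxy group has this effect.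

From the compounds shown here alone, it remains open whether methoxycarbonyl to carboxy would lower the number without the phenyl, which only a carboxymethyl group on the same nitrogen could show. Going by these compounds, it is equally open whether the free carboxylic acid itself is required, or whether a primary amide or a tetrazole in its place would give a number in the same range as compound 4.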